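Replacing methoxy with 1H-pyrrol-1-yl in compound 3

The source may report more compounds than this note shows. Statements on the series, on what has been measured and on what is new or still open speak of the compounds shown alone.

For the measured compounds named here, compound 2 `COc1cc(C)ccc1N1CCN(CCCNc2ncccc2C(=O)N(C)C)CC1` gives 39.8 nM in a functional assay on aorta for antagonist activity at Alpha-1D adrenergic receptor (Rattus norvegicus) (on this read-out lower numbers stand for tighter binding and higher numbers for weaker binding), one of only two numbers measured; the other, compound 1 `COc1cc(O)ccc1N1CCN(CCCNc2ncccc2C(=O)N(C)C)CC1` at 79.4 nM, lies within the scatter of it. That pair yields a 2.0-fold lower number from compound 1 to compound 2 (0.30 log units; within the scatter). Compound 3 `Cc1ccc(N2CCN(CCCNc3ncccc3C(=O)N(C)C)CC2)c(-n2cccc2)c1` differs from compound 2 by 1H-pyrrol-1-yl in place of methoxy on an aromatic carbon. Going by the values given here, the single measured step concerns a different position and does not bear on this exchange, so for compound 3 the expected step is a 1.3-fold higher number from compound 2 to compound 3 (0.10 log units; within the scatter), nothing beyond the scatter but with wide uncertainty. The estimate for compound 3 in this assay is 50 nM, between 10 nM and 250 nM.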

Compound 3, dissociation constant: 12.6 nM
For compound 3 the middle estimate is 4.0-fold (0.60 log units) above the measured one; the measured number falls inside the stated range.
By their numbers in this assay, from the lowest: compound 3; then compounds 2 and 1 (each within the scatter of the next).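

At the aromatic carbon ortho to a large group, exchanging methoxy for 1H-pyrrol-1-yl in this assay gives a modest change beyond the scatter (a 3.2-fold lower number from compound 2 to compound 3 (0.50 log units; beyond the scatter)). For the compounds shown here, this is the first change at this position and, unlike the earlier step, it exceeds the scatter, showing that the larger five-membered aromatic ring is accepted here without any loss. Nothing available accounts for this step. As far as these compounds go, it remains open whether phenyl, ethoxy or an amine at this position would follow the same direction. Whether the step would persist with hydroxy in place of the methyl group is also unresolved.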